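A few compounds are considered here, and "the series" means these few. Any claim that something is new, unique, unknown or untested is made for them only; others in the source may bear on it.

Measured compounds:
- compound 1 `C=CS(=O)(=O)c1cc(C(F)(F)F)cc(C(F)(F)F)c1`
- compound 2 `C=Cc1cc(C(F)(F)F)cc(C(F)(F)F)c1`

In an ADME assay for pharmacokinetics, read by HPLC, in phosphate buffer, with a stated time of 72 h, at pH 7.4, tested at 250 uM (on this read-out higher numbers stand for a longer-lived compound and lower numbers for a shorter-lived compound), compound 1 gives < 0.017 h, which is a limit of the assay. In this assay compound 2 gives > 50 h, also a limit of the assay. The one step recorded so far, an at least 2900-fold higher number from compound 1 to compound 2 (3.46 log units; beyond the scatter), joins two limits rather than two numbers, as shown by the limit of < 0.017 h in this assay, at which 1 of the 2 values shown sits, and (the limit of > 50 h in this assay, at which 1 of the 2 values shown sits), so its true size is not known beyond being large. Compound 2 therefore stands at the upper edge of what this assay can report, with no numeric value.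

Compound 3 `C#Cc1cc(C(F)(F)F)cc(C(F)(F)F)c1` differs from compound 2 by ethynyl in place of vinyl on an aromatic carbon. Within the data shown here, no measured step bears on this change; the only step recorded concerns the vinylsulfonyl group of compound 1. With compound 2 at > 50 h, the expectation for compound 3 is no step beyond the scatter, a step that the limit leaves unreadable from compound 2 to compound 3, and most likely a further limit. Compound 3 is estimated at 100 h, in the range 40 h to 400 h.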

Compound 3, half-life: 2.4 h
For compound 3 the middle estimate is 42-fold (1.62 log units) above the measured one; measured number below the stated range.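

Ethynyl in place of vinyl on an aromatic carbon gives an at least 20-fold lower number from compound 2 to compound 3 (1.31 log units; beyond the scatter) in this assay, so the read-out at this position responds to the two-carbon group itself, even with no sulfonyl present. Ethynyl in place of vinylsulfonyl gives an at least 140-fold higher number from compound 1 to compound 3 (2.14 log units; beyond the scatter), which places compound 3 between the other two with the only numeric value shown, 2.4 h. Each step has a limit of the assay at one end and therefore gives only a minimum size: the limit of < 0.017 h in this assay, at which 1 of the 3 values shown sits; the limit of > 50 h in this assay, at which 1 of the 3 values shown sits.

Still open, going by these compounds, is whether the step from vinyl to ethynyl holds on a core without the two trifluoromethyl groups. Also open, on these data alone, is where a nitrile or an aminomethyl group on the same aromatic carbon would fall in this assay.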